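This account rests on a few compounds, and the source may have more. Where it says the series, first, only, none or still open, it means among the compounds named here.

Compound 1, `O=c1ccoc2cc(OCc3cn(Cc4ccc(Cl)cc4Cl)nn3)ccc12`: > 100000 nM
Compound 2, `O=c1ccoc2cc(OCc3cn(Cc4ccccc4Cl)nn3)ccc12`: > 100000 nM
Compound 3, `O=c1ccoc2cc(OCc3cn(Cc4ccc([N+](=O)[O-])cc4)nn3)ccc12`: > 100000 nM

These three compounds share one core and differ only in the group attached to the saturated chain carbon bound to an aromatic nitrogen. In a functional assay on SGC-7901 cells (Homo sapiens) for cytotoxicity, read by MTT assay, with a stated time of 48 h (on this read-out lower numbers stand for stronger inhibition and higher numbers for weaker inhibition), compound 1 gives > 100000 nM, which is a limit of the assay and not a number. Compound 2 likewise gives > 100000 nM, again a limit. Compound 3 gives > 100000 nM, also a limit. Because every value sits at the limit of > 100000 nM in this assay, at which 3 of the 3 values shown sit, the steps among them cannot be read: a step that the two limits leave unreadable from compound 1 to compound 2, a step that the two limits leave unreadable from compound 1 to compound 3 and a step that the two limits leave unreadable from compound 2 to compound 3.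

Compound 4, `N#Cc1ccc(Cn2cc(COc3ccc4c(=O)ccoc4c3)nn2)cc1`, has not yet been measured. It differs from compound 1 in one place: 4-cyanophenyl in place of 2,4-dichlorophenyl on a saturated chain carbon bound to an aromatic nitrogen. The measured steps that bear on it, each swapping the group at the same place, were all unreadable, so no direction and no size of step beyond the scatter can be foreseen in this assay; each change of this group so far has left the value at the limit. Compound 4 is therefore expected to give about 200000 nM in this assay, within a range from 60000 nM to 800000 nM. The step this estimate means, a step that the limit leaves unreadable from compound 1 to compound 4, is an expectation only, and the most likely outcome is once more a limit rather than a number.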

Compound 4, half-maximal inhibitory concentration: > 100000 nM
Compound 4: a limit, no number (the forecaster's own chance of this, stated with the estimate: 80%); the middle value is on the limit's open side.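

In this assay compound 4 gives > 100000 nM, a limit and not a number. No step between compound 4 and compound 1, compound 2 or compound 3 can be read, because all four stop at the same limit: the limit of > 100000 nM in this assay, at which 4 of the 4 values shown sit.

The compounds shown leave open whether any group at this place on the shared core would give a measurable number in this assay.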